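The source may hold more compounds than are shown below. What is called first, only, known or untested is meant among the compounds shown, and "the series" means these compounds.

Compound 1 `Nc1cccc(S(=O)(=O)Oc2ccc(-c3cncn3C3CCN(C(=O)c4ccc(Cl)c(C(F)(F)F)c4)CC3)cc2)c1` gives 565 nM in an assay on HEK293 cells for antagonist activity at P2X purinoceptor 7 (Homo sapiens), read by fluorescence, with a stated time of 2 h; on this read-out lower numbers stand for stronger inhibition and higher numbers for weaker inhibition.
Compound 2 `N#Cc1cccc(S(=O)(=O)Oc2ccc(-c3cncn3C3CCN(C(=O)c4ccc(Cl)c(C(F)(F)F)c4)CC3)cc2)c1` gives 73 nM in this assay.
Compound 3 `O=C(NC1CC1)c1cccc(S(=O)(=O)Oc2ccc(-c3cncn3C3CCN(C(=O)c4ccc(Cl)c(C(F)(F)F)c4)CC3)cc2)c1` gives 88 nM in this assay.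

Compound 3 stands second of these three numbers; the nearer step is a 1.2-fold higher number from compound 2 to compound 3 (0.08 log units; within the scatter), within the scatter, while the further one is far larger, a 6.4-fold lower number from compound 1 to compound 3 (0.81 log units; beyond the scatter). Compound 4 `CCN(CC)C(=O)c1cccc(S(=O)(=O)Oc2ccc(-c3cncn3C3CCN(C(=O)c4ccc(Cl)c(C(F)(F)F)c4)CC3)cc2)c1` differs from compound 3 by diethylamino in place of cyclopropylamino on a carbonyl carbon. The step that bears most on this is a 1.2-fold higher number from compound 2 to compound 3 (0.08 log units; within the scatter), where two quite different groups at this position gave numbers within the scatter; only the amino group of compound 1 stood apart, as a 7.7-fold lower number from compound 1 to compound 2 (0.89 log units; beyond the scatter) shows. Going by the values given here, no measured step tests the loss of the amide hydrogen on an otherwise similar group. The expected step in this assay is therefore a 1.3-fold higher number from compound 3 to compound 4 (0.10 log units; within the scatter), not beyond the scatter. Compound 4 is estimated at 110 nM, with a range of 45 nM to 270 nM.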

Compound 4, half-maximal inhibitory concentration: 202 nM
Compound 4: middle estimate off by 1.8-fold (0.26 log units), on the low side, and the stated range covers the measured number.
By their numbers in this assay, from the lowest: compounds 2 and 3 (each within the scatter of the next); then compound 4; then compound 1.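

Replacing cyclopropylamino with diethylamino on the carbonyl carbon is not a neutral swap (a 2.3-fold higher number from compound 3 to compound 4 (0.36 log units; beyond the scatter)), so the group on this carbonyl does affect the number, even though the nitrile and cyclopropylcarbamoyl groups gave numbers within the scatter. Diethylcarbamoyl falls between the other groups, on one side of the nitrile (a 2.8-fold higher number from compound 2 to compound 4 (0.44 log units; beyond the scatter)) and on the other of the amino group (a 2.8-fold lower number from compound 1 to compound 4 (0.45 log units; beyond the scatter)). No measurement here explains this shift.

Because this change removes both the amide hydrogen and the ring, the two cannot be told apart. Ethylamino or dimethylamino on the same carbonyl could separate them, and a carboxylic acid in place of the amide remains open.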